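This account rests on a few compounds, and the source may have more. Where it says the series, first, only, none or still open, it means among the compounds named here.

Working notes on the series, read in a functional assay on MDA-MB-231 cells (Homo sapiens) for inhibition, read by sulforhodamine B assay; a lower number here means a stronger inhibitor of growth, a higher number a weaker inhibitor of growth. Compound 1 `O=C(CCC1=CCCN(Cc2ccc(F)cc2)C1=O)NO` stands at "not determined" (no result reported), so it offers no number for comparison. Compound 2 `Cc1ccc(CN2CCC=C(CCC(=O)NO)C2=O)cc1` gives 1430 nM. Compound 3 `O=C(CCC1=CCCN(Cc2ccc(NC(=O)c3ccccc3)cc2)C1=O)NO` gives 6030 nM, the higher of the two numbers and so the weaker growth inhibitor of the pair.

Compound 4 `O=C(CCC1=CCCN(Cc2ccc(Br)cc2)C1=O)NO` has not yet been measured. The change to it is bromo in place of benzamido on an aromatic carbon, para to a large group.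

Within the data shown here, only one measured step bears on this: a 4.2-fold higher number from compound 2 to compound 3 (0.62 log units; beyond the scatter), a modest step with benzamido in place of methyl. Among the measured compounds shown here, compound 4 also loses the benzamido, but carries bromo instead of methyl, and no measured compound shows what bromo does here. A step of similar size towards a lower number is therefore expected, resting on that single comparison. The expected step is a 3.8-fold lower number from compound 3 to compound 4 (0.58 log units; beyond the scatter). For compound 4 the estimated value is 1600 nM, with an expected range of 650 nM to 4000 nM.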

Compound 4, concentration for 50% growth inhibition: 1630 nM
Compound 4: middle estimate off by 1.0-fold (0.01 log units), on the low side, within the range that was stated.
By their numbers in this assay, from the lowest: compounds 2 and 4 (each within the scatter of the next); then compound 3.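

In this assay, among these compounds, the change at this aromatic carbon, para to a large group, gives a 3.7-fold lower number from compound 3 to compound 4 (0.57 log units; beyond the scatter) and so puts a second small group against the benzamido, where the earlier compounds offered methyl alone. Bromo in place of methyl gives a 1.1-fold higher number from compound 2 to compound 4 (0.06 log units; within the scatter), so these two groups cannot be told apart at this position, and among the three compounds with numbers only the benzamido compound stands apart. Nothing measured on these compounds accounts for either step.

Steps involving compound 1 cannot be read, so the fluoro group gives no further comparison at this position. From the compounds shown here alone, it remains open whether an amine, a carboxylic acid or a methoxy group on this carbon would stay with methyl and bromo or move towards the benzamido.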